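The source may report more compounds than this note shows. Statements on the series, on what has been measured and on what is new or still open speak of the compounds shown alone.

Working notes on the series in a functional assay on NCI-H460 cells (Homo sapiens) for inhibition, read by sulforhodamine B assay, with a stated time of 48 h; on this read-out lower numbers stand for higher toxicity in this test and higher numbers for lower toxicity in this test. Compound 1 `COc1ccc(-c2cc(/C=C/C(=O)c3ccc(OC)c(OC)c3)[nH]n2)cc1` gives 22800 nM, and compound 3 `COc1ccc(-c2cc(/C=C/C(=O)c3ccc(N)cc3)[nH]n2)cc1` gives 20900 nM; these two values lie within the scatter of each other. Compound 2 `COc1cc(-c2cc(/C=C/C(=O)c3ccc(Cl)c(Cl)c3)[nH]n2)cc(OC)c1OC` returns only a limit of the assay, > 100000 nM, with no number. Compound 2 thus stands at the limit of > 100000 nM in this assay, at which 1 of the 3 values shown sits. Compound 4 `COc1ccc(C(=O)/C=C/c2cc(-c3cc(OC)c(OC)c(OC)c3)n[nH]2)cc1OC`, not yet measured, differs from compound 2 in one place: 3,4-dimethoxyphenyl in place of 3,4-dichlorophenyl on a carbonyl carbon. Compound 1 carries the same 3,4-dimethoxyphenyl on the carbonyl carbon and gives 22800 nM, so compound 4 is expected to come in with a lower number than compound 2 shows, by a step of an at least 4.0-fold lower number from compound 2 to compound 4 (0.60 log units; beyond the scatter) that goes beyond the scatter. Compound 4 is estimated at 25000 nM, within a range from 8000 nM to 90000 nM.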

Compound 4, concentration lethal to 50% of the cells: 7860 nM
Compound 4: the middle estimate sits 3.2-fold (0.50 log units) above what was measured, outside the stated range (below it).
By their numbers in this assay, from the lowest: compound 4; then compounds 3 and 1 (each within the scatter of the next). At a limit, above all of these: compound 2.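

In this assay, the position on the carbonyl carbon responds strongly to this change: 3,4-dimethoxyphenyl in place of 3,4-dichlorophenyl gives an at least 12-fold lower number from compound 2 to compound 4 (1.10 log units; beyond the scatter). Going by these compounds alone, this is the first step that can be read across a single place. As far as these compounds go, compound 2 gives only a limit, not a number, so the true size of the step stays unknown: the limit of > 100000 nM in this assay, at which 1 of the 4 values shown sits.

Open, from the compounds shown here alone, is whether a 3,4-dihydroxyphenyl or a 3,4-difluorophenyl on the carbonyl carbon would read like compound 4 or like compound 2. Also open, going by these compounds, is whether the same change gives a similar step on another core.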